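Trimming the Butylsulfanyl Chain Down to Methoxy

This account rests on a few compounds, and the source may have more. Where it says the series, first, only, none or still open, it means among the compounds named here.

Compound 3 `CCCCSc1nc(N)c2nc(O)n(Cc3ccccc3)c2n1` gives 0.01 uM in a functional assay (spleen, spleen) for activation, with Mus musculus as the target (on this read-out lower numbers stand for an effect already at smaller amounts and higher numbers for an effect only at larger amounts of compound), the lowest number among the three measured compounds, and both of its neighbours lie beyond the scatter from it. Compound 1 `CCSc1nc(N)c2nc(O)n(Cc3ccccc3)c2n1` gives 0.1 uM in this assay, and compound 2 `CNc1nc(N)c2nc(O)n(Cc3ccccc3)c2n1` gives 1 uM. Two steps lead to compound 3: a 10-fold lower number from compound 1 to compound 3 (1.00 log units; beyond the scatter), and a 100-fold lower number from compound 2 to compound 3 (2.00 log units; beyond the scatter). The third measured step, a 10-fold higher number from compound 1 to compound 2 (1.00 log units; beyond the scatter), runs the other way, so that the shortest group on this aromatic carbon sits at the high end of the numbers.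

Compound 4 `COc1nc(N)c2nc(O)n(Cc3ccccc3)c2n1` has not yet been measured. It differs from compound 3 in one place: methoxy in place of butylsulfanyl on an aromatic carbon. Both steps that reach compound 3 bear on this change, since they tie the long sulfanyl chain to the low number, and the methylamino group of compound 2 resembles methoxy far more than butylsulfanyl does. A large upward step is therefore expected, a 100-fold higher number from compound 3 to compound 4 (2.00 log units; beyond the scatter), on the order of the step seen from compound 2 to compound 3 in reverse. Compound 4 is estimated to give 1 uM in this assay, within a range from 0.1 uM to 10 uM.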

Compound 4, minimum effective concentration: 0.1 uM
Estimate against measurement, compound 4: 10-fold (1.00 log units) above, and the stated range covers the measured number.
By their numbers in this assay, from the lowest: compound 3; then compounds 1 and 4 (each within the scatter of the next); then compound 2.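

In this assay, the aromatic carbon between two ring nitrogen atoms does not need a sulfur-linked chain to reach the middle of the measured numbers: there is no change at the digits printed from compound 1 to compound 4 (within the scatter), so methoxy and ethylsulfanyl cannot be told apart on this read-out. The linking atom of a short group does count, however, for the comparison with methylamino gives a 10-fold lower number from compound 2 to compound 4 (1.00 log units; beyond the scatter), so these two short groups do not behave alike at this position. Butylsulfanyl still holds the lowest number of the four, with a 10-fold higher number from compound 3 to compound 4 (1.00 log units; beyond the scatter), and this step is beyond the scatter, as are the steps from compound 3 to compound 1 and compound 2.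

Whether the longer chain would also lower the number when linked through oxygen or nitrogen remains open, as the compounds shown include neither butoxy nor butylamino, so the effects of chain length and linking atom cannot yet be separated. Nothing available here explains why these groups differ.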